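Benzylamino in place of propylamino on the shared core

A few compounds are considered here, and "the series" means these few. Any claim that something is new, unique, unknown or untested is made for them only; others in the source may bear on it.

Going by the values given here, compound 1 `CCCNc1cc(-c2ccccc2)nc2cc(OC)cc(OC)c12` gives 970 nM in a functional assay on HCT-116 cells (Homo sapiens) for inhibition, read by MTT assay, with a stated time of 72 h (a lower number here means a stronger inhibitor, a higher number a weaker inhibitor), the lowest of the three numbers so far. Compound 2 `CCCCNc1cc(-c2ccccc2)nc2cc(OC)cc(OC)c12` gives 3050 nM, and compound 3 `COc1cc(OC)c2c(-n3ccnc3)cc(-c3ccccc3)nc2c1` gives 42400 nM. The step of a 3.1-fold higher number from compound 1 to compound 2 (0.50 log units; beyond the scatter) is modest, while a 44-fold higher number from compound 1 to compound 3 (1.64 log units; beyond the scatter) and a 14-fold higher number from compound 2 to compound 3 (1.14 log units; beyond the scatter) are large, so the alkylamino group appears to matter more than the chain length across these three compounds.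

Compound 4 `COc1cc(OC)c2c(NCc3ccccc3)cc(-c3ccccc3)nc2c1` is not yet measured. It differs from compound 1 as follows: phenyl in place of ethyl on a saturated chain carbon bound to a nitrogen on an aromatic ring. Among the compounds with values here, no measured pair shows the same change; the nearest guide is compound 1 to compound 2, where extending the chain lowered the reading modestly, and the two alkylamino compounds both stand far from compound 3. A larger group on the chain carbon is expected to move in the same direction as a 3.1-fold higher number from compound 1 to compound 2 (0.50 log units; beyond the scatter), probably by a modest amount. For compound 4 the estimated step is a 2.6-fold higher number from compound 1 to compound 4 (0.41 log units; beyond the scatter), giving an expected value of 2500 nM, with a likely range from 800 nM to 8000 nM.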

Compound 4, half-maximal inhibitory concentration: 12000 nM
Estimate against measurement, compound 4: 4.8-fold (0.68 log units) below; the whole stated range lies below it.
By their numbers in this assay, from the lowest: compound 1; then compound 2; then compound 4; then compound 3.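

At this position on the shared core, the ring on the chain matters more than chain length alone: in this assay the phenyl for ethyl change gives a 12-fold higher number from compound 1 to compound 4 (1.09 log units; beyond the scatter) and stands as a large step, while the comparison with the butylamino compound gives a 3.9-fold higher number from compound 2 to compound 4 (0.59 log units; beyond the scatter) and remains beyond the scatter. Keeping the amino nitrogen therefore does not by itself hold the reading near that of the propylamino compound, since the benzylamino group recovers only modestly from the imidazole compound, with a 3.5-fold lower number from compound 3 to compound 4 (0.55 log units; beyond the scatter) as the step. No measurement here offers a reason for these steps.

A phenethylamino or cyclohexylmethylamino group would help separate the effect of the phenyl ring from that of its placement on the chain carbon. Going by these compounds, how an ethylamino chain would read also remains open.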